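The source may hold more compounds than are shown below. What is called first, only, known or untested is meant among the compounds shown, and "the series" means these compounds.

The series shares a single amide-linked core, carrying a pyridinylmethoxy-substituted benzamide on one side and a substituted phenyl ring on the other. Compound 1 `Cc1cc(Cl)c(-c2ncc[nH]2)cc1NC(=O)c1ccc(OCc2ccccn2)cc1` bears a chloro group and an imidazolyl ring on that phenyl ring. In a physicochemical assay for lipophilicity (on this read-out higher numbers stand for higher lipophilicity and lower numbers for lower lipophilicity), compound 1 returns only a limit of the assay, > 3. Going by the values given here, compound 2 `Cc1ncc(-c2cc(NC(=O)c3ccc(OCc4ccccn4)cc3)c(C)cc2C)[nH]1` carries two methyl groups on the same ring together with a 2-methyl-1H-imidazol-5-yl group, and in this assay compound 2 gives 2.8, the only numeric value available, the other reading being (the limit of > 3 in this assay, at which 1 of the 2 values shown sits).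

Compound 3 `Cc1cc(C)c(-c2ccc(N)cn2)cc1NC(=O)c1ccc(OCc2ccccn2)cc1` differs from compound 2 in one place: 5-aminopyridin-2-yl in place of 2-methyl-1H-imidazol-5-yl on an aromatic carbon. Among the compounds with values here, no measured step between two compounds differing in a single place exists in this set, so the expectation for compound 3 rests on the reading of compound 2 alone. From that reading, the step of a number 0.10 log units higher from compound 2 to compound 3 (within the scatter) is expected to be small, not clearly beyond the usual scatter, in either direction. Compound 3 is therefore estimated at 2.9 in this assay, within a range from 2.3 to 3.5.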

Compound 3, distribution coefficient: 3.2
Compound 3: middle estimate off by 0.30 log units, on the low side, within the range that was stated.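

Going by these compounds alone, the exchange of 2-methyl-1H-imidazol-5-yl for 5-aminopyridin-2-yl gives the first step in this set between two compounds differing in one place, and in this assay that step is a number 0.40 log units higher from compound 2 to compound 3 (beyond the scatter). It shows that the read-out responds to the ring carried on this aromatic carbon, which is ortho to a methyl group and para to a methyl group, when a five-membered aromatic ring with 2 hetero atoms gives way to a six-membered aromatic ring with 1 hetero atom. Ring size, ring hetero atoms, heavy-atom count and hydrogen-bond acceptor count all change together in this one step, and the step does not separate them.

Going by these compounds, whether a pyridine ring without the amine, or with a carboxylic acid or a methoxy group in place of the amine, would read closer to compound 2 or to compound 3 remains open. Compound 1 also stays outside any numerical comparison, its reading being only a limit of the assay: the limit of > 3 in this assay, at which 1 of the 3 values shown sits.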